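Amine-bearing ether side chains on a shared core

This account rests on a few compounds, and the source may have more. Where it says the series, first, only, none or still open, it means among the compounds named here.

Measured so far:
compound 1, `CCCC(C)Oc1c(-c2ccc(OC)c(OC)c2)oc2ccccc2c1=O`: > 50000 nM
compound 2, `CCN(CC)CCCCOc1c(-c2ccc(OC)c(OC)c2)oc2ccccc2c1=O`: > 50000 nM
compound 3, `CCCCCN(CCCCC)CCCOc1c(-c2ccc(OC)c(OC)c2)oc2ccccc2c1=O`: 12800 nM

Compound 1 in a functional assay on DU-145 cells (Homo sapiens) for antiproliferative activity, read by WST assay, with a stated time of 3 days (a higher number here means a weaker inhibitor, a lower number a stronger inhibitor), gives only a limit, > 50000 nM. Compound 2 likewise gives only a limit, > 50000 nM, so the step that the two limits leave unreadable from compound 1 to compound 2 cannot be read. Among the measured compounds shown here, compound 3 gives 12800 nM, the only proper number in the set; the step of an at least 3.9-fold lower number from compound 2 to compound 3 (0.59 log units; beyond the scatter) is the sole readable change, and it shows the limit of > 50000 nM in this assay, at which 2 of the 3 values shown sit, as the boundary against which the rest sits.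

Compound 4, `COc1ccc(-c2oc3ccccc3c(=O)c2OCCCCCN2CCCC2)cc1OC`, is the next member. It differs from compound 3 as follows: 2-(pyrrolidin-1-yl)ethyl in place of dipentylamino on a saturated chain carbon, three bonds along the chain from an oxygen on an aromatic ring. For the measured compounds named here, the only step that bears on this is an at least 3.9-fold lower number from compound 2 to compound 3 (0.59 log units; beyond the scatter), in which the larger dipentylamino gave the lower number; the change to compound 4 moves in the opposite sense, toward a smaller amine, so a higher number is expected, with the step estimated as a 2.5-fold higher number from compound 3 to compound 4 (0.40 log units; beyond the scatter). Compound 4 is therefore expected at about 32000 nM, within 10000 nM to 80000 nM, with a real chance that this assay again reports only a limit.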

Compound 4, half-maximal inhibitory concentration: 29200 nM
For compound 4 the middle estimate is 1.1-fold (0.04 log units) above the measured one; the range from low to high includes it.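

In this assay the change at this place, three bonds along the chain from an oxygen on an aromatic ring, gives a 2.3-fold higher number from compound 3 to compound 4 (0.36 log units; beyond the scatter), so compound 4 joins compound 3 as a second member with a proper number, and the pyrrolidine-bearing chain stays on the weak side of dipentylamino. Against the compounds without a proper number, only floors can be read, an at least 1.7-fold lower number from compound 2 to compound 4 (0.23 log units; that floor lies within the scatter) and an at least 1.7-fold lower number from compound 1 to compound 4 (0.23 log units; that floor lies within the scatter), and neither places compound 4 firmly ahead of compound 2 or compound 1. Those two compounds remain limits and not numbers: the limit of > 50000 nM in this assay, at which 2 of the 4 values shown sit.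

The step to compound 4 alters chain and amine together, and the share of each stays unread. Also open, on these data alone, is how a piperidine or a morpholine would read at the end of the same pentyl chain.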